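Adding a Chloro Group on Two Related Cores

This account rests on a few compounds, and the source may have more. Where it says the series, first, only, none or still open, it means among the compounds named here.

The measured compounds, with the concentration for half-maximal growth inhibition in a functional assay on OVCAR-8 cells (Homo sapiens) for inhibition, read by sulforhodamine B assay, with a stated time of 48 h; on this read-out higher numbers stand for weaker inhibition of growth and lower numbers for stronger inhibition of growth:

Compound 1 `N#Cc1c(-c2nnc(-c3nn(-c4ccccc4)c(-c4ccccc4)c3C#N)c3nn(-c4ccccc4)cc23)nn(-c2ccccc2)c1-c1ccccc1`: 9820 nM
Compound 2 `N#Cc1c(-c2nnc(-c3nn(-c4ccccc4)c(-c4ccccc4)c3C#N)c3nn(-c4ccc(Cl)cc4)cc23)nn(-c2ccccc2)c1-c1ccccc1`: 61800 nM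
Compound 3 `N#Cc1c(-c2nnc(-c3ccccc3)c3nn(-c4ccccc4)cc23)nn(-c2ccccc2)c1-c1ccccc1`: 68000 nM

Compound 1 and compound 2 differ only by chloro in place of hydrogen on an aromatic carbon. On this read-out the change gave a 6.3-fold higher number from compound 1 to compound 2 (0.80 log units; beyond the scatter), so the chloro-bearing compound inhibited growth more weakly. Compound 3 carries a smaller core than compound 1; the difference between the two cores is not broken down here. Its value and that of compound 2 lie close to each other, within the usual scatter, so no order between them can be claimed.

Compound 4 `N#Cc1c(-c2nnc(-c3ccccc3)c3nn(-c4ccc(Cl)cc4)cc23)nn(-c2ccccc2)c1-c1ccccc1` is compound 3 with chloro in place of hydrogen on an aromatic carbon, the same change that turned compound 1 into compound 2. In this assay the step of a 2.2-fold higher number from compound 3 to compound 4 (0.34 log units; beyond the scatter) is therefore expected to point the same way as a 6.3-fold higher number from compound 1 to compound 2 (0.80 log units; beyond the scatter), though compound 3 starts from 68000 nM, which already sits near the weak end and makes a smaller movement plausible. Compound 4 is thus estimated at 150000 nM, with a likely range of 60000 nM to 400000 nM.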

Compound 4, concentration for 50% growth inhibition: 9230 nM
Compound 4: the middle estimate sits 16-fold (1.21 log units) above what was measured, outside the stated range (below it).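

In this assay, changing phenyl to 4-chlorophenyl gave a 7.4-fold lower number from compound 3 to compound 4 (0.87 log units; beyond the scatter), so on this core the chloro-bearing compound inhibited growth more strongly, the opposite of what the same change did on the core of compound 1. The two steps point in opposite directions, and the gap between them is larger than chance scatter would explain: the same change on two cores in this assay, a 6.3-fold higher number (0.80 log units; beyond the scatter) from compound 1 to compound 2 and a 7.4-fold lower number (0.87 log units; beyond the scatter) from compound 3 to compound 4, 46-fold (1.67 log units) apart, beyond the scatter of two such steps.

This shows that, in this series, the effect of this change cannot simply be carried from one core to another, so a result on one core is a poor guide to the other; it does not show why the cores respond differently, and two pairs of compounds set no general rule for other cores.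

On these data alone, it remains open whether this reversal is specific to chloro or would also appear with other groups in the same place. Fluoro, methoxy or an amine on each of the two cores would help to settle that question.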